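Series notes: the step from compound 3 to compound 4

The source may hold more compounds than are shown below. What is called first, only, known or untested is meant among the compounds shown, and "the series" means these compounds.

In a physicochemical assay for solubility, read by HPLC, in phosphate buffer, measured as kinetic solubility, at pH 7.4 (on this read-out higher numbers stand for higher solubility and lower numbers for lower solubility), compound 1 (`CC(=O)c1cc(-c2ccc(S(N)(=O)=O)cc2)n(-c2ccc(Cl)cc2)n1`) gives 86800 nM, compound 2 (`NS(=O)(=O)c1ccc(-c2cc(C(=O)CC3CCCC3)nn2-c2ccc(Cl)cc2)cc1`) gives 2600 nM and compound 3 (`NS(=O)(=O)c1ccc(-c2cc(C(=O)N3CC4CC4C3)nn2-c2ccc(Cl)cc2)cc1`) gives 36600 nM, the second highest of the three numbers. Compound 4 (`NS(=O)(=O)c1ccc(-c2cc(C(=O)NC3CC3)nn2-c2ccc(Cl)cc2)cc1`) is still unmeasured. Its change, on the carbonyl carbon, is a group of 4 heavy atoms (3 carbon, 1 nitrogen; one three-membered non-aromatic ring of carbon only) in place of a group of 6 heavy atoms (5 carbon, 1 nitrogen; one three-membered non-aromatic ring of carbon only, one five-membered non-aromatic ring with 1 hetero atom), on a carbonyl carbon, and cyclopropylamino enters there.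

Within the data shown here, no measured compound carries cyclopropylamino, so the evidence is indirect. All three measured steps change the group on the same carbonyl carbon: a 33-fold lower number from compound 1 to compound 2 (1.52 log units; beyond the scatter), a 2.4-fold lower number from compound 1 to compound 3 (0.38 log units; beyond the scatter) and a 14-fold higher number from compound 2 to compound 3 (1.15 log units; beyond the scatter). The two large steps each involve compound 2, whose group holds 6 carbon atoms and no nitrogen. Compound 3 and compound 4 both keep nitrogen at this place, so the modest 2.4-fold lower number from compound 1 to compound 3 (0.38 log units; beyond the scatter) is the better guide to size. The direction is weakly supported. The expected change is a 2.3-fold lower number from compound 3 to compound 4 (0.36 log units; beyond the scatter), a modest step. For compound 4 the estimated value is 16000 nM, within an expected range of 5000 nM to 50000 nM.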

Compound 4, solubility: 72600 nM
Compound 4: middle estimate off by 4.5-fold (0.66 log units), on the low side; measured number outside the range, above it.
By their numbers in this assay, from the lowest: compound 2; then compounds 3, 4 and 1 (each within the scatter of the next, the first and the last beyond it).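

In this assay, the exchange of the larger nitrogen-bearing group for cyclopropylamino on this carbonyl carbon gives a 2.0-fold higher number from compound 3 to compound 4 (0.30 log units; within the scatter), so the two groups cannot be told apart here. Cyclopropylamino also cannot be told apart from methyl at this place, with a 1.2-fold lower number from compound 1 to compound 4 (0.08 log units; within the scatter), whereas in place of cyclopentylmethyl it gives a 28-fold higher number from compound 2 to compound 4 (1.45 log units; beyond the scatter), a large step that sets compound 2 apart from compound 4. Nothing available accounts for these steps.

The compounds shown do not separate the contribution of the nitrogen from that of the ring, since no cyclopentylamino group stands as a direct partner to cyclopentylmethyl. A plain amino group or a dimethylamino group on this carbonyl carbon would also test whether the ring is needed at all.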